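The source may hold more compounds than are shown below. What is called first, only, known or untested is meant among the compounds shown, and "the series" means these compounds.

Measured compounds:
Compound 1, `N#CCCn1nc(-c2ccc(OCc3cccc(Cl)c3)cc2)oc1=S`: 160 nM
Compound 2, `N#CCCn1nc(-c2ccc(OCc3ccc(Cl)cc3)cc2)oc1=S`: 690 nM

Among the compounds with values here, in an assay for inhibition of Amine oxidase [flavin-containing] B (Rattus norvegicus) (a lower number here means a stronger inhibitor, a higher number a weaker inhibitor), compound 2 gives 690 nM, the higher of the two numbers at hand; compound 1 is its only neighbour, and the single measured step, a 4.3-fold higher number from compound 1 to compound 2 (0.63 log units; beyond the scatter), lies beyond the scatter. That step moves the chloro from one position of the benzyl ring to another and says nothing about exchanging the group itself.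

Compound 3, `N#CCCn1nc(-c2ccc(OCc3ccc([N+](=O)[O-])cc3)cc2)oc1=S`, differs from compound 2 by nitro in place of chloro on an aromatic carbon, para to a large group. Within the data shown here, no measured step bears on this exchange, since the only comparison available concerns where a chloro sits rather than what replaces it. With nothing in the data pointing either way, the change from compound 2 to compound 3 is expected to stay within the scatter, as a 1.0-fold higher number from compound 2 to compound 3 (0.01 log units; within the scatter). Compound 3 is therefore estimated at 700 nM in this assay, with a range from 220 nM to 2200 nM to reflect the absence of a guiding step.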

Compound 3, half-maximal inhibitory concentration: 4300 nM
For compound 3 the middle estimate is 6.1-fold (0.79 log units) below the measured one, outside the stated range (above it).
By their numbers in this assay, from the lowest: compound 1; then compound 2; then compound 3.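

In this assay, the exchange of the group itself now has a measured size: a 6.2-fold higher number from compound 2 to compound 3 (0.79 log units; beyond the scatter) shows that what sits on the ring of the 4-chlorophenyl group matters, and not only where the chloro stands. The earlier step concerned the chloro's location alone, whereas this one shows that keeping the place and replacing chloro with nitro also moves the number beyond the scatter, and in the same direction as moving the chloro from compound 1 to compound 2. The widest gap among the three, a 27-fold higher number from compound 1 to compound 3 (1.43 log units; beyond the scatter), combines a change of group with a change of place, so it cannot be credited to either one alone, and nothing in the material at hand explains the higher number seen with nitro.

From the compounds shown here alone, whether chloro is favoured over other groups at this place remains open, since a single exchange cannot show how a methoxy group, an amine or a carboxylic acid would compare there. Also open, going by these compounds, is whether nitro in place of chloro would give a similar step at the ring place that the chloro holds in compound 1.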